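Replacing 3-fluorophenyl with 4-methylphenyl: what to expect

A few compounds are considered here, and "the series" means these few. Any claim that something is new, unique, unknown or untested is made for them only; others in the source may bear on it.

Two close relatives have been tested so far: compound 1 `C=C(Br)C(=O)Nc1cccc(/C=C/C(=O)Nc2ccc(F)cc2)c1` and compound 2 `C=C(Br)C(=O)Nc1cccc(/C=C/C(=O)Nc2cccc(F)c2)c1`. In a functional assay on LoVo cells (Homo sapiens) for inhibition, read by MTT assay, with a stated time of 72 h (on this read-out higher numbers stand for weaker inhibition and lower numbers for stronger inhibition), compound 1 gives 4800 nM and compound 2 gives 1000 nM, the lower of the two numbers and so the stronger inhibition. The next molecule, compound 3 `C=C(Br)C(=O)Nc1cccc(/C=C/C(=O)Nc2ccc(C)cc2)c1`, keeps the shared core and carries 4-methylphenyl in place of 3-fluorophenyl on an amide-type nitrogen.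

Among the compounds with values here, only one measured step bears on this change: a 4.8-fold lower number from compound 1 to compound 2 (0.68 log units; beyond the scatter). That modest step leaves a 4-fluorophenyl group behind, and the 4-methylphenyl group of compound 3 resembles it in name, so part of that gain may be lost. Within the data shown here, no measured step exchanges fluorine for methyl, which makes this a loose guide. A modest move to a higher number in this assay is therefore expected, meaning somewhat weaker inhibition. The estimated change is a 2.8-fold higher number from compound 2 to compound 3 (0.45 log units; beyond the scatter). For compound 3 the expected value is 2800 nM, with an estimated range from 900 nM to 8000 nM.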

Compound 3, half-maximal inhibitory concentration: 1500 nM
The estimate for compound 3 lay 1.9-fold (0.27 log units) above the measured number, within the range that was stated.
By their numbers in this assay, from the lowest: compounds 2 and 3 (each within the scatter of the next); then compound 1.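

In this assay, the swap of 3-fluorophenyl for 4-methylphenyl on the amide-type nitrogen gives a 1.5-fold higher number from compound 2 to compound 3 (0.18 log units; within the scatter), so these two groups cannot be told apart on this read-out, even though both the substituent and its place on the ring differ. The comparison with the other fluorinated compound adds something new: methyl in place of fluoro gives a 3.2-fold lower number from compound 1 to compound 3 (0.51 log units; beyond the scatter), which shows that the high number of compound 1 does not simply follow from having a group at the 4-position of this ring, as the first pair alone might have suggested, since the identity of that group also matters here. No measurement in hand explains why fluoro and methyl part ways at this spot, so the numbers describe the change without accounting for it.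

Still open, from the compounds shown here alone, is how 3-methylphenyl, which would pair the methyl group with the other ring position, or plain phenyl with no substituent, would compare with these three compounds. Also open, going by these compounds, is whether a ring carrying an amine or a carboxylic acid would stay close to compound 2 and compound 3 or move away from them.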